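The source may report more compounds than this note shows. Statements on the series, on what has been measured and on what is new or still open speak of the compounds shown alone.

Measured so far in a functional assay on Capan-2 cells (Homo sapiens) for inhibition, read by MTT assay, with a stated time of 72 h; on this read-out lower numbers stand for stronger inhibition of growth and higher numbers for weaker inhibition of growth:

Compound 1, `O=S(=O)(NCCCNCc1ccccc1Cl)c1cc(C(F)(F)F)cc(C(F)(F)F)c1`, gives 13000 nM.
Compound 2, `O=S(=O)(NCCCNCc1ccc(Cl)c(C(F)(F)F)c1)c1cc(C(F)(F)F)cc(C(F)(F)F)c1`, gives 9100 nM.
Compound 3, `O=S(=O)(NCCCNCc1ccc(Br)cc1)c1cc(C(F)(F)F)cc(C(F)(F)F)c1`, gives 2000 nM.

Compound 3 stands lowest of the three numbers, with compound 2 nearest and compound 1 furthest. Compound 4, `COc1ccccc1CNCCCNS(=O)(=O)c1cc(C(F)(F)F)cc(C(F)(F)F)c1`, differs from compound 3 as follows: 2-methoxyphenyl in place of 4-bromophenyl on a saturated chain carbon bound to an amine nitrogen. Among the measured compounds shown here, two steps bear on this. The change of compound 1 to compound 3 gave a 6.5-fold lower number from compound 1 to compound 3 (0.81 log units; beyond the scatter), and that of compound 2 to compound 3 gave a 4.6-fold lower number from compound 2 to compound 3 (0.66 log units; beyond the scatter). Both show the 4-bromophenyl of compound 3 giving the lowest number, while the 2-chlorophenyl of compound 1 gave the highest. Compound 4 carries a 2-methoxyphenyl, so a step back toward higher numbers is expected, about a 4.0-fold higher number from compound 3 to compound 4 (0.60 log units; beyond the scatter). Compound 4 is estimated at 8000 nM, within 3000 nM to 25000 nM.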

Compound 4, concentration for 50% growth inhibition: 6000 nM
Compound 4: middle estimate off by 1.3-fold (0.12 log units), on the high side; the measured number falls inside the stated range.
By their numbers in this assay, from the lowest: compound 3; then compounds 4, 2 and 1 (each within the scatter of the next, the first and the last beyond it).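

In this assay, 2-methoxyphenyl in place of 4-bromophenyl gives a 3.0-fold higher number from compound 3 to compound 4 (0.48 log units; beyond the scatter) and so leaves compound 3 with the lowest number of the four. Methoxy in place of chloro gives a 2.2-fold lower number from compound 1 to compound 4 (0.34 log units; beyond the scatter) as a change of the aromatic substituent alone, whereas replacing 4-chloro-3-(trifluoromethyl)phenyl gives a 1.5-fold lower number from compound 2 to compound 4 (0.18 log units; within the scatter) and stays within the scatter. Nothing given here explains these differences.

Still open, as far as these compounds go, is how a plain phenyl or a pyridine would read at this place. From the compounds shown here alone, whether a longer chain in the shared core would shift these numbers is also open.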